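A few compounds are considered here, and "the series" means these few. Any claim that something is new, unique, unknown or untested is made for them only; others in the source may bear on it.

Measured compounds:
compound 1 `CCNc1nnc(-c2cc(-c3ccc(F)cc3F)ccc2O)s1` — 50.2%
compound 2 `Oc1ccc(-c2ccc(F)cc2F)cc1-c1n[nH]c(=S)n1-c1ccccc1` — 36.3%
compound 3 `Cc1ccc(Nc2nnc(-c3cc(-c4ccc(F)cc4F)ccc3O)o2)cc1` — 33.8%

In a functional assay on the whole organism (strain BALB/c) for inhibition, with Mus musculus as the target, read by paw edema, with a stated time of 4 h, at a dose of 50 mg/kg by the oral route (a lower number here means less inhibition, a higher number more inhibition at the dose given (going by the name of the read-out)), compound 1 gives 50.2%, the highest of the three numbers. Compound 2 gives 36.3%, a number lower by a margin beyond the scatter, and compound 3, which gives 33.8%, lies furthest from compound 1, again beyond the scatter. No two of these compounds differ in only one place, so no single step can be read from them.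

The unmeasured compound 4 `COc1ccc(Nc2nnc(-c3cc(-c4ccc(F)cc4F)ccc3O)s2)cc1` differs from compound 1 in one place: 4-methoxyphenyl in place of ethyl on a nitrogen on an aromatic ring. Compound 3 also carries an arylamino group on its core and sits well under compound 1 in this assay, but it differs from compound 1 in more than this one place, so its value is only a hint, not a step. On that hint, the step from compound 1 to compound 4 is expected to be a fall of moderate size, around the edge of the scatter, rather than no change: a number 10.2 percentage points lower from compound 1 to compound 4 (beyond the scatter). Compound 4 is therefore expected to give 40% in this assay, with a range from 28% to 52%.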

Compound 4, a percentage reported as inhibition, in the whole organism at one dose (the size of the read-out at that dose, not a potency): 55.3%
For compound 4 the middle estimate is 15.3 percentage points below the measured one; measured number above the stated range.
By their numbers in this assay, from the lowest: compounds 3 and 2 (each within the scatter of the next); then compounds 1 and 4 (each within the scatter of the next).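

In this assay, putting 4-methoxyphenyl in place of ethyl on the nitrogen gives a number 5.1 percentage points higher from compound 1 to compound 4 (within the scatter), so the read-out does not separate the two compounds even though the entering group brings a six-membered aromatic ring and 8 heavy atoms where ethyl had 2. Going by these compounds alone, this is the first step that can be read from these compounds, and it shows that, at this position and at the single dose used, the ethylamino group of compound 1 can be exchanged for the much larger (4-methoxyphenyl)amino group of compound 4 with no loss beyond the scatter. Nothing available explains why the number holds across this change.

The compounds shown leave open whether the methoxy group contributes anything, since a plain phenyl, a 4-chlorophenyl or a benzyl on the same nitrogen would be needed to tell, and whether a longer chain such as hexyl or an amine-bearing chain would fit this position equally well. They also leave open whether compound 1 and compound 4 would still match at other doses, as a reading at one dose gives the size of the effect and not a potency.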